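Turning two ring stereocentres in a peroxide acid

The source may report more compounds than this note shows. Statements on the series, on what has been measured and on what is new or still open speak of the compounds shown alone.

Compound 1 `C=C1CCCC(C)(C)C1CC[C@]1(C)CC[C@@H]([C@@H](C)C(=O)O)OO1` is a peroxide-bearing acid tested in a functional assay on ACHN cells (Homo sapiens) for inhibition; on this read-out lower numbers stand for stronger inhibition of growth and higher numbers for weaker inhibition of growth. There compound 1 gives only a limit, > 10000 nM. Compound 1 stands at the limit of > 10000 nM in this assay, at which 1 of the 2 values shown sits. The methyl ester compound 2 `C=C1CCCC(C)(C)C1CC[C@]1(C)CC[C@H]([C@@H](C)C(=O)OC)OO1`, which differs in stereochemistry as well, gives 480 nM in this assay. Compound 3 `C=C1CCCC(C)(C)C1CC[C@@]1(C)CC[C@H]([C@@H](C)C(=O)O)OO1` keeps every atom of compound 1; the change is the two compounds have the same atoms and bonds; at least one stereo element is drawn with a configuration in one of them and without one in the other: 2 of 4 stereo elements differ; a stereocentre at a saturated ring carbon is drawn R in compound 1 and S in compound 3; a stereocentre at a saturated ring carbon is drawn S in compound 1 and R in compound 3. Going by the values given here, no measured pair shows what such a change does, so the expected step of an at least 1.6-fold lower number from compound 1 to compound 3 (0.22 log units; that floor lies within the scatter) rests on little and could fall in either direction. Compound 3 is estimated at 6000 nM, within 1000 nM to 30000 nM.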

Compound 3, concentration for 50% growth inhibition: 7830 nM
For compound 3 the middle estimate is 1.3-fold (0.12 log units) below the measured one; measured number inside the range.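

Inverting the two ring stereocentres while keeping the acid gives the first step measured for this change (an at least 1.2-fold lower number from compound 1 to compound 3 (0.10 log units; that floor lies within the scatter)). Compound 3 gives a measured number (7830 nM) in this assay. Compound 1 gives only a limit, so the step has a floor but no known size, and that floor lies within the scatter: the limit of > 10000 nM in this assay, at which 1 of the 3 values shown sits.

Going by these compounds, each stereocentre's separate contribution remains open, since both differ at once. So does whether an amide or a primary alcohol in place of the carboxylic acid would change growth inhibition on this stereochemistry.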